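Swapping the ester of compound 1 for a dimethylamide

This account rests on a few compounds, and the source may have more. Where it says the series, first, only, none or still open, it means among the compounds named here.

Measured so far:
compound 1 `CC(/C=C/CC(C)CCCC(C)C)=C\C(=O)OC(C)C` — 7.15
compound 2 `CC(=O)OC(C)(C)CCCC(C)C/C=C/C(C)=C/C(=O)OC(C)C` — 5.98
compound 3 `COC(C)(C)C(O)CCC(C)C/C=C/C(C)=C/C(=O)OC(C)C` — 3.86

In a physicochemical assay for lipophilicity (on this read-out higher numbers stand for higher lipophilicity and lower numbers for lower lipophilicity), compound 1 stands highest of the three; compound 2 is next, with a number 1.17 log units lower from compound 1 to compound 2 (beyond the scatter), and compound 3 is furthest, with a number 3.29 log units lower from compound 1 to compound 3 (beyond the scatter). Compound 4 `CC(/C=C/CC(C)CCCC(C)C)=C\C(=O)N(C)C` differs from compound 1 at the carbonyl end: dimethylamino in place of isopropoxy on a carbonyl carbon. Among the compounds with values here, none of the measured steps touches this carbonyl; all three concern the saturated chain, so they give no direct guide. Going from an ester to a dimethylamide is nevertheless expected to lower the read-out well beyond the scatter, with an estimated step of a number 1.95 log units lower from compound 1 to compound 4 (beyond the scatter). Compound 4 is therefore estimated at 5.2, in a range from 4.5 to 5.9.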

Compound 4, partition coefficient: 4.94
For compound 4 the middle estimate is 0.26 log units above the measured one, and the stated range covers the measured number.
By their numbers in this assay, from the lowest: compound 3; then compound 4; then compound 2; then compound 1.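

Within the data shown here, compound 4 brings the first change at the carbonyl end. In this assay, dimethylamino in place of isopropoxy on a carbonyl carbon gives a number 2.21 log units lower from compound 1 to compound 4 (beyond the scatter), so the read-out responds to this position as well as to the saturated chain. No measurement at hand explains the size of this step. Still open, from the compounds shown here alone, is how a carboxylic acid, a methyl ester or a diethylamide would read on this same carbonyl. Also open, going by these compounds, is whether dimethylamino would bring a similar step when paired with the acetoxy chain of compound 2.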